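From Acyl Sulfonamide to Aryl Sulfonamide at the Receptor

The compounds below may be only part of what the source reports. "The series", "measured", "known", "first", "only" and "open" are said of these compounds alone.

Compound 3 `O=C(NS(=O)(=O)c1ccc(NC(=O)c2ccc(Cl)cc2Cl)cc1)c1ccccc1` carries a benzoyl group on its sulfonamide nitrogen. In a functional assay on HEK293 cells for agonist activity at probable G-protein coupled receptor 27 (Homo sapiens), read by a luciferase reporter and beta-arrestin recruitment, with a stated time of 10 min (on this read-out higher numbers stand for larger maximal responses and lower numbers for smaller maximal responses), compound 3 gives "not determined" (no result reported), so its standing cannot be read from a number. Compound 4 `Cc1ccccc1NS(=O)(=O)c1ccc(NC(=O)c2ccc(Cl)cc2Cl)cc1` differs from it in one place: 2-methylphenyl in place of benzoyl on a sulfonamide nitrogen. Two measured compounds share the core of compound 4 and differ from each other only in what sits on the sulfonyl sulfur. Compound 1 `CN(c1ccccc1)S(=O)(=O)c1ccc(NC(=O)c2ccc(Cl)cc2Cl)cc1` gives 50% in this assay, and compound 2 `O=C(Nc1ccc(S(=O)(=O)Nc2cccc(Cl)c2)cc1)c1ccc(Cl)cc1Cl` gives 40%. The step of a number 10 percentage points lower from compound 1 to compound 2 (within the scatter) stays within the usual scatter, so exchanging one substituent on the sulfonyl nitrogen for another has not shifted the maximal response in these data. Going by the values given here, no measured step runs from compound 3 to compound 4, and the expectation therefore rests on compounds 1 and 2 alone. Compound 4 is expected to land near those two, with an estimated maximal response of 45% and a range from 25% to 65%.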

Compound 4, largest response reached (Emax), in percent of the reference or control that the assay uses: 32%
Beside the measured number, compound 4's estimate is 13 percentage points above it, within the range that was stated.
By their numbers in this assay, from the lowest: compounds 4, 2 and 1 (each within the scatter of the next, the first and the last beyond it).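

Exchanging 3-chlorophenyl for 2-methylphenyl on a sulfonamide nitrogen gives a number 8 percentage points lower from compound 2 to compound 4 (within the scatter) and so leaves these two aryl groups indistinguishable in this assay. Going by these compounds alone, exchanging methyl(phenyl)amino for (2-methylphenyl)amino on a sulfonyl sulfur gives a number 18 percentage points lower from compound 1 to compound 4 (beyond the scatter) and is the first step at this position to pass the scatter, which shows that the maximal response can shift with the group here, though only modestly. No available evidence accounts for this step. As far as these compounds go, it remains open whether the maximal response would hold with a saturated amine such as morpholine on the sulfonyl sulfur, or with a carboxylic acid on the aryl ring. From the compounds shown here alone, how a longer chain on the sulfonamide nitrogen would compare with 2-methylphenyl also remains open.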